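Aryl swap on the ring nitrogen: projecting compound 4

A few compounds are considered here, and "the series" means these few. Any claim that something is new, unique, unknown or untested is made for them only; others in the source may bear on it.

Measured in a functional assay on CHO cells with adenosine receptor A1 (Homo sapiens) as the target, read by cAMP accumulation and immunoassay, with a stated time of 6 min, tested at 0.01 uM; a lower number here means a stronger effect, a higher number a weaker effect of the compound at the concentration tested:

compound 1 `Nc1scc(CN2CCN(c3ccc(Cl)c(C(F)(F)F)c3)CC2)c1C(=O)c1ccc(Cl)cc1` gives -2.5%
compound 2 `Nc1scc(CN2CCN(c3ccc(C(F)(F)F)cc3)CC2)c1C(=O)c1cccc(C(F)(F)F)c1` gives -12%
compound 3 `Nc1scc(CN2CCN(c3cc(F)cc(F)c3)CC2)c1C(=O)c1ccc(Cl)cc1` gives -13%

Compound 1 carries the highest of the three numbers in this assay. Compound 2 sits nearest, within the scatter of compound 1, so no order between these two can be read. For the measured compounds named here, compound 3 lies furthest, and the single-change step a number 10.5 percentage points lower from compound 1 to compound 3 (beyond the scatter) is the only measured step that falls beyond the scatter.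

Compound 4 `Nc1scc(CN2CCN(c3cc(F)ccc3F)CC2)c1C(=O)c1ccc(Cl)cc1` is not yet measured in this assay. It differs from compound 1 in one place: 2,5-difluorophenyl in place of 4-chloro-3-(trifluoromethyl)phenyl on an amine nitrogen in a ring.

The step from compound 1 to compound 3 bears most directly on this change, since both replace the same group on the same ring nitrogen with a difluorophenyl ring and differ only in where the two fluorines sit. That step was modest and downward. The step from compound 2 offers no single-place comparison and is within the scatter of compound 1.

On this basis a modest downward step is expected for compound 4 in this assay, of about a number 7.5 percentage points lower from compound 1 to compound 4 (within the scatter). Compound 4 is therefore estimated at -10%, with a range from -25% to 5%.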

Compound 4, a percentage reported as activity, at one concentration (the size of the read-out at that concentration, not a potency): 3.1%
The estimate for compound 4 lay 13.1 percentage points below the measured number, and the stated range covers the measured number.
By their numbers in this assay, from the lowest: compounds 3, 2, 1 and 4 (each within the scatter of the next, the first and the last beyond it).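

In this assay, the two difluorophenyl groups on the amine nitrogen do not read alike, with a number 16.1 percentage points higher from compound 3 to compound 4 (beyond the scatter) showing that the fluorine pattern on this ring, and not merely the presence of two fluorines, separates the values at this position. Exchanging 4-chloro-3-(trifluoromethyl)phenyl for 2,5-difluorophenyl gives a number 5.6 percentage points higher from compound 1 to compound 4 (within the scatter) and no order can be read for that pair, whereas the exchange for 3,5-difluorophenyl gives a number 10.5 percentage points lower from compound 1 to compound 3 (beyond the scatter) and so the earlier shift does not extend to every difluorophenyl replacement. No available evidence bears on the origin of the difference between the two difluorophenyl groups.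

Still open, from the compounds shown here alone, is whether a single fluorine on the phenyl ring, a pyridine ring or a non-aromatic group such as cyclohexyl on the same nitrogen would stay with compound 3 or with compound 4 in this assay when the rest of the molecule is held constant. These numbers also come from one concentration, which leaves the potency of the compounds undefined and shows only the size of the read-out at that concentration.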